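This account rests on a few compounds, and the source may have more. Where it says the series, first, only, none or still open, it means among the compounds named here.

Measured compounds:
compound 1 `COCCNc1ccc2c(C(=O)NCC3CCC(F)(F)CC3)c(Cl)ccc2n1` — in an assay for antagonist activity at P2X purinoceptor 7 (Homo sapiens), read by ELISA, with a stated time of 30 min (on this read-out lower numbers stand for stronger inhibition and higher numbers for weaker inhibition), compound 1 gives 180 nM
compound 2 `COCCOc1ccc2c(C(=O)NCC3CCC(F)(F)CC3)c(Cl)ccc2n1` — in this assay compound 2 gives 140 nM
compound 3 `O=C(NCC1CCC(F)(F)CC1)c1c(Cl)ccc2ncccc12` — in this assay compound 3 gives 220 nM

Compound 2 has the lowest of the three numbers in this assay, yet it cannot be set apart from the others: a 1.3-fold lower number from compound 1 to compound 2 (0.11 log units; within the scatter) and a 1.6-fold higher number from compound 2 to compound 3 (0.20 log units; within the scatter), both within the scatter. The third pair likewise shows a 1.2-fold higher number from compound 1 to compound 3 (0.09 log units; within the scatter). The unmeasured compound 4 `O=C(NCC1CCC(F)(F)CC1)c1c(Cl)ccc2nc(C3CCCC3)ccc12` differs from compound 2 in one place: cyclopentyl in place of 2-methoxyethoxy on an aromatic carbon. All three measured steps concern this same position on the shared core, where hydrogen, (2-methoxyethyl)amino and 2-methoxyethoxy have been tried, and none of them moved the number in this assay beyond the scatter. A cyclopentyl group, a ring with no hydrogen-bond acceptors, has not been tried there, so the comparison is indirect. On this basis compound 4 is expected to show no step beyond the scatter, a 1.3-fold higher number from compound 2 to compound 4 (0.11 log units; within the scatter). Compound 4 is therefore estimated at 180 nM in this assay, with a range from 70 nM to 500 nM.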

Compound 4, half-maximal inhibitory concentration: 160 nM
Compound 4: middle estimate off by 1.1-fold (0.05 log units), on the high side, and the stated range covers the measured number.
By their numbers in this assay, from the lowest: compounds 2, 4, 1 and 3 (each within the scatter of the next).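

In this assay, a cyclopentyl ring, with 0 hydrogen-bond acceptors and only carbon atoms, takes the place on the aromatic carbon next to the ring nitrogen without any step beyond the scatter: a 1.1-fold higher number from compound 2 to compound 4 (0.06 log units; within the scatter), a 1.1-fold lower number from compound 1 to compound 4 (0.05 log units; within the scatter) and a 1.4-fold lower number from compound 3 to compound 4 (0.14 log units; within the scatter). Among these four compounds, then, the oxygen atoms of 2-methoxyethoxy are not required to keep the number where it stands, and a carbon-only ring sits level with both chains and with hydrogen. Nothing available accounts for this flat result.

As far as these compounds go, what remains open is whether any group at this position moves the number beyond the scatter at all. A carboxylic acid, a piperazine or a phenyl ring there would test this, and so would a longer chain than 2-methoxyethoxy.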